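This account rests on a few compounds, and the source may have more. Where it says the series, first, only, none or still open, it means among the compounds named here.

In a functional assay on NCI-H460 cells (Homo sapiens) (a higher number here means a weaker inhibitor, a lower number a stronger inhibitor), three compounds built on one shared core have been measured so far. Compound 1 (`COc1cc(NC(C)CCCNC(=O)NCCCO)c2ncccc2c1`) gives > 100000 nM, which is a limit of the assay and not a number. Among the compounds with values here, compound 2 (`COc1cc(NC(C)CCCNC(=O)NCCCCCO)c2ncccc2c1`) gives 2000 nM, the only true number in the set. Compound 3 (`COc1cc(NC(C)CCCNC(=O)NO)c2ncccc2c1`) gives > 100000 nM, again a limit.

Compound 4 (`CCOC(=O)NCCCC(C)Nc1cc(OC)cc2cccnc12`) starts from compound 3 and carries ethoxy in place of hydroxyamino on a carbonyl carbon. Within the data shown here, no measured step makes this exact change. The nearest ones also alter the group at the end of the same urea-like stretch. There is an at least 50-fold higher number from compound 2 to compound 3 (1.69 log units; beyond the scatter), and there is an at least 50-fold lower number from compound 1 to compound 2 (1.69 log units; beyond the scatter), both large, while a step that the two limits leave unreadable from compound 1 to compound 3 tells nothing. Among the measured compounds shown here, the end group can therefore matter a great deal, but compound 2, at 2000 nM, is the only guide to how strong this series can get, and its 5-hydroxypentyl end is much longer than ethoxy. A return to the ceiling is quite possible for compound 4, given (the limit of > 100000 nM in this assay, at which 2 of the 3 values shown sit).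

A modest move to a lower number is expected, read as an at least 3.3-fold lower number from compound 3 to compound 4 (0.52 log units; beyond the scatter). For compound 4 the estimated value is 30000 nM, with an expected range from 6000 nM to 100000 nM.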

Compound 4, half-maximal inhibitory concentration: 38000 nM
Compound 4: middle estimate off by 1.3-fold (0.10 log units), on the low side; low and high end bracket the measured number.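

In this assay, putting ethoxy on the carbonyl carbon brings the series down from the ceiling, with an at least 2.6-fold lower number from compound 3 to compound 4 (0.42 log units; beyond the scatter) and an at least 2.6-fold lower number from compound 1 to compound 4 (0.42 log units; beyond the scatter). Compound 3 gives > 100000 nM, a limit and not a number, and compound 1 carries the same limit. A measurable value therefore does not require a hydrogen-bond donor in the group at this place, since ethoxy counts 0 of them against 2 for hydroxyamino, yet this small group does not match the longest end shown, with a 19-fold higher number from compound 2 to compound 4 (1.28 log units; beyond the scatter).

Compound 2 differs from compound 4 both in the atom joined to the carbonyl carbon and in the length and hydroxy end of the chain, so the compounds shown cannot tell which of these carries that step. Going by these compounds, how a pentyloxy group on the same carbonyl carbon would read remains open, as does a (5-aminopentyl)amino group, which would keep the chain of compound 2 but replace its hydroxy with an amine.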